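A Diethylaminomethyl Group Added to Compound 1

A few compounds are considered here, and "the series" means these few. Any claim that something is new, unique, unknown or untested is made for them only; others in the source may bear on it.

For the measured compounds named here, compound 1, `COc1cc2c(cc1OC)C(=O)/C(=C/c1cccc(O)c1)CO2`, is one of two compounds measured in an assay on isolated protein for inhibition of Amine oxidase [flavin-containing] A (Homo sapiens), read by fluorescence, with a stated time of 30 min, tested at 20 uM (on this read-out lower numbers stand for less inhibition and higher numbers for more inhibition at the one concentration tested (going by the name of the read-out)), where compound 1 gives 21.9%. Compound 2, `COc1cc2c(cc1OC)C(=O)/C(=C/c1ccc(CN3CCCCC3)c(O)c1)CO2`, gives 24.6% in this assay, and the step of a number 2.7 percentage points higher from compound 1 to compound 2 (within the scatter) shows that this change left the read-out essentially unmoved. Compound 3, `CCN(CC)Cc1c(O)cccc1/C=C1\COc2cc(OC)c(OC)cc2C1=O`, differs from compound 1 by (diethylamino)methyl in place of hydrogen on an aromatic carbon. Going by the values given here, because the only comparable step, a number 2.7 percentage points higher from compound 1 to compound 2 (within the scatter), stayed within the scatter, a similarly small step is expected for compound 3, namely a number 2.1 percentage points higher from compound 1 to compound 3 (within the scatter). Compound 3 is therefore estimated at 24%, with a range from 12% to 38%.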

Compound 3, a percentage reported as inhibition, at one concentration (the size of the read-out at that concentration, not a potency): 8.5%
Beside the measured number, compound 3's estimate is 15.5 percentage points above it; measured number outside the range, below it.
By their numbers in this assay, from the lowest: compound 3; then compounds 1 and 2 (each within the scatter of the next).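

For the compounds shown here, this aromatic carbon, ortho to a hydroxy group and ortho to a large group, is a place where a substituent can change the result: in this assay the (diethylamino)methyl group gives a number 13.4 percentage points lower from compound 1 to compound 3 (beyond the scatter) and is the first step here beyond the scatter. Adding an amine-bearing group to compound 1 therefore does not always leave the read-out unmoved, as the earlier step of a number 2.7 percentage points higher from compound 1 to compound 2 (within the scatter) might have suggested. Nothing available explains this drop.

On these data alone, it remains open whether a plain methyl or a (piperidin-1-yl)methyl on this same carbon would lower the number as well. That would help separate the role of the amine from that of the carbon chain attached to it.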